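Aryl amide exchange on the piperidine sulfamoylurea series

The source may hold more compounds than are shown below. What is called first, only, known or untested is meant among the compounds shown, and "the series" means these compounds.

In a functional assay on the whole organism (blood) with Rattus norvegicus as the target, with stated times of 24 h and 1 h, at a dose of 15 mg/kg by the intraperitoneal route (on this read-out lower numbers stand for a weaker effect and higher numbers for a stronger effect at the one dose given), three compounds have been run so far. Compound 1 `O=C(NC[C@@H]1C[C@@H]2C=C[C@@H]1C2)NS(=O)(=O)N1CCC(CCNC(=O)c2cnsc2)CC1` gives 14%, compound 2 `Cc1ncsc1C(=O)NCCC1CCN(S(=O)(=O)NC(=O)NC[C@@H]2C[C@@H]3C=C[C@@H]2C3)CC1` gives 25%, and compound 3 `CSc1ccc(C(F)(F)F)cc1C(=O)NCCC1CCN(S(=O)(=O)NC(=O)NC2CCCCC2)CC1` gives 24%. For the measured compounds named here, the one step that changes a single place is a number 11 percentage points higher from compound 1 to compound 2 (beyond the scatter). Compound 3 stands second highest of the three numbers; its gap to compound 2 is within the scatter, and its gap to compound 1 is also within the scatter, so no order among compound 3 and either neighbour can be read from these values.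

Compound 4 `O=C(NC1CCCCC1)NS(=O)(=O)N1CCC(CCNC(=O)c2nsc3ccccc23)CC1` is not yet measured. It differs from compound 3 by a group of 9 heavy atoms (7 carbon, 1 nitrogen, 1 sulfur; one five-membered aromatic ring with 2 hetero atoms, one six-membered aromatic ring of carbon only) in place of a group of 12 heavy atoms (8 carbon, 3 fluorine, 1 sulfur; one six-membered aromatic ring of carbon only), on a carbonyl carbon. Going by the values given here, the only step on record at the same carbonyl carbon is the one from compound 1 to compound 2, which was modest and beyond the scatter; it concerns a different pair of groups, so it bears on the present change only as an indication that swaps at this carbonyl carbon have so far moved this assay by a modest amount. Given this, the expected step is a number 2 percentage points lower from compound 3 to compound 4 (within the scatter), in no firm direction. The estimate for compound 4 in this assay is 22%, with a range from 8% to 38%.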

Compound 4, a percentage reported as activity, at one dose (the size of the read-out at that dose, not a potency): 17%
Compound 4: the middle estimate sits 5 percentage points above what was measured, within the range that was stated.
By their numbers in this assay, from the lowest: compounds 1, 4, 3 and 2 (each within the scatter of the next, the first and the last beyond it).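

In this assay, the exchange on the carbonyl carbon gives a number 7 percentage points lower from compound 3 to compound 4 (within the scatter), so this position accepts a group with one five-membered aromatic ring with 2 hetero atoms and one six-membered aromatic ring of carbon only in place of the single six-membered aromatic ring of compound 3 without a step beyond the scatter. Unlike the earlier step on record at this carbonyl carbon, a number 11 percentage points higher from compound 1 to compound 2 (beyond the scatter), this pair shows that the 3 fluorine atoms of the leaving group are not needed for compound 4 to stay within the scatter of compound 3 at the one dose given, although the change in the group is large by atom count and ring count. No measurement on record offers an explanation of this result.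

The compounds shown leave open how an unsubstituted phenyl ring or a pyridine ring would read on this carbonyl carbon, and whether an amine or a carboxylic acid on the aromatic group would move the number beyond the scatter. Also open, from the compounds shown here alone, is whether the same exchange gives a similar step when the other end of the molecule is that of compound 1.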